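Cytotoxicity notes: amine substituent changes, compounds 1 to 4

This account rests on a few compounds, and the source may have more. Where it says the series, first, only, none or still open, it means among the compounds named here.

compound 1 `Cc1cn([C@@H]2O[C@H](CO[Si](C)(C)C(C)(C)C)[C@@]3(OS(=O)(=O)C=C3NC(N)=O)[C@H]2O[Si](C)(C)C(C)(C)C)c(=O)n(C)c1=O`: 16000 nM in a functional assay on HEL cells (Homo sapiens) for cytotoxicity, read by microscopy; a higher number here means that more compound is tolerated, a lower number that less compound is tolerated
compound 2 `COC(=O)CCNC1=CS(=O)(=O)O[C@@]12[C@@H](CO[Si](C)(C)C(C)(C)C)O[C@@H](n1cc(C)c(=O)n(C)c1=O)[C@@H]2O[Si](C)(C)C(C)(C)C`: a limit, see below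
compound 3 `Cc1cn([C@@H]2O[C@H](CO[Si](C)(C)C(C)(C)C)[C@@]3(OS(=O)(=O)C=C3NCC(=O)C(=O)N3CCC3)[C@H]2O[Si](C)(C)C(C)(C)C)c(=O)n(C)c1=O`: 65000 nM in this assay

Compound 3 holds the highest of the two numbers in this assay. Among the measured compounds shown here, the one other number is reached by a 4.1-fold higher number from compound 1 to compound 3 (0.61 log units; beyond the scatter). Compound 2 gives >= 400000 nM, a limit of the assay rather than a number, and the step of an at least 6.1-fold lower number from compound 2 to compound 3 (0.78 log units; beyond the scatter) is therefore itself a limit.

Compound 4 `Cc1cn([C@@H]2O[C@H](CO[Si](C)(C)C(C)(C)C)[C@@]3(OS(=O)(=O)C=C3NC(=O)NC(=O)c3ccccc3)[C@H]2O[Si](C)(C)C(C)(C)C)c(=O)n(C)c1=O` carries the change (benzoylcarbamoyl in place of (((azetidin-1-yl)carbonyl)carbonyl)methyl on an amine nitrogen). The step of a 4.1-fold higher number from compound 1 to compound 3 (0.61 log units; beyond the scatter) bears on it: replacing carbamoyl raised the number, and compound 4 returns a carbamoyl, here benzoylcarbamoyl. A modest drop back toward compound 1 is expected, a 2.2-fold lower number from compound 3 to compound 4 (0.34 log units; beyond the scatter). Compound 4 is estimated at 30000 nM, within 10000 nM to 100000 nM.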

Compound 4, minimum cytotoxic concentration: >= 80000 nM
Compound 4: only a limit was reported; the forecaster's own chance of this, stated with the estimate: 10%; middle value at least 2.6-fold (0.42 log units) from the limit.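

For compound 4 the read-out in this assay is a limit and not a number: the limit of >= 80000 nM in this assay, at which 1 of the 4 values shown sits.

Benzoyl in place of hydrogen on the amide-type nitrogen gives an at least 5.0-fold higher number from compound 1 to compound 4 (0.69 log units; beyond the scatter), so a carbamoyl unit on the amine nitrogen does not by itself hold the number down. Benzoylcarbamoyl in place of (((azetidin-1-yl)carbonyl)carbonyl)methyl gives an at least 1.2-fold higher number from compound 3 to compound 4 (0.09 log units; that floor lies within the scatter), a floor that sets no order, and the step between the limits of compound 2 and compound 4 cannot be read.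

Where the true number of compound 4 lies remains open. Also open, going by these compounds, is whether acetyl on the same amide-type nitrogen, or a carboxylic acid in place of the methyl ester of 2-(methoxycarbonyl)ethyl, would shift the number.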